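The compounds below may be only part of what the source reports. "The series", "measured", "known", "first", "only" and "open" are said of these compounds alone.

In a functional assay on SMMC-7721 cells (Homo sapiens) for antiproliferative activity, read by MTT assay, with a stated time of 48 h (on this read-out higher numbers stand for weaker inhibition and lower numbers for stronger inhibition), compound 3 (`Cn1cc(C2=C(c3nn(CCCn4cccc4)c4ncccc34)C(=O)N(c3ccccc3)C2=O)c2ccccc21`) stands at > 100000 nM, which is a limit of the assay and not a number. Compound 2 (`Cn1cc(C2=C(c3nn(CCn4ccnc4)c4ncccc34)C(=O)N(c3ccccc3)C2=O)c2ccccc21`) also gives only a limit, > 100000 nM. Together they sit at the limit of > 100000 nM in this assay, at which 2 of the 3 values shown sit. Compound 1 (`Cn1cc(C2=C(c3nn(CCCN4CCCCC4)c4ncccc34)C(=O)N(c3ccccc3)C2=O)c2ccccc21`) alone gives a number, 3050 nM.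

The change under study leads to compound 4 (`Cn1cc(C2=C(c3nn(CCCCn4ccnc4)c4ncccc34)C(=O)N(c3ccccc3)C2=O)c2ccccc21`): (1H-imidazol-1-yl)methyl in place of 1H-pyrrol-1-yl on a saturated chain carbon, three bonds along the chain from an aromatic nitrogen. In words, (1H-imidazol-1-yl)methyl comes in place of 1H-pyrrol-1-yl on a saturated chain carbon, three bonds along the chain from an aromatic nitrogen.

Two large steps bear on this: an at least 32-fold higher number from compound 1 to compound 2 (1.51 log units; beyond the scatter), and an at least 32-fold higher number from compound 1 to compound 3 (1.51 log units; beyond the scatter). Both leave the piperidin-1-yl of compound 1 for a five-membered aromatic ring, which compound 4 keeps. The remaining step, a step that the two limits leave unreadable from compound 2 to compound 3, cannot be read. In this assay, among the compounds with values here, no large step is therefore expected, at most a modestly lower number, and compound 4 may well stay at the limit.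

The estimated change is an at least 1.2-fold lower number from compound 3 to compound 4 (0.09 log units; that floor lies within the scatter). For compound 4 the expected value is 80000 nM, with an estimated range of 15000 nM to 100000 nM.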

Compound 4, half-maximal inhibitory concentration: 1760 nM
Beside the measured number, compound 4's estimate is 45-fold (1.66 log units) above it, and the stated range ends above it.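

In this assay, a five-membered aromatic ring at the chain end does not by itself cost the activity: with the imidazole kept, lengthening the chain alone gives an at least 56-fold lower number from compound 2 to compound 4 (1.75 log units; beyond the scatter), and changing ring and chain together gives an at least 56-fold lower number from compound 3 to compound 4 (1.75 log units; beyond the scatter). The 4-(1H-imidazol-1-yl)butyl group also reads level with the piperidine chain of compound 1, with a 1.7-fold lower number from compound 1 to compound 4 (0.24 log units; within the scatter). Both large steps start from a limit and not a number, so their full size stays unknown: the limit of > 100000 nM in this assay, at which 2 of the 4 values shown sit.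

On these data alone, how much of the step from compound 3 belongs to the ring and how much to the chain stays open, as does where a 3-(1H-imidazol-1-yl)propyl or 4-(1H-pyrrol-1-yl)butyl group would read. As far as these compounds go, a longer chain such as 5-(1H-imidazol-1-yl)pentyl, or a dimethylamino end group, is equally open.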